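A few compounds are considered here, and "the series" means these few. Any claim that something is new, unique, unknown or untested is made for them only; others in the source may bear on it.

Measured in a physicochemical assay for solubility, with a stated time of 24 h, tested at 30 mg/mL; a higher number here means a more soluble compound, a lower number a less soluble compound:
- compound 1 (`CC(=O)N1CC(CC(=O)NO)(NS(=O)(=O)c2ccc(SCc3cc(C)nc4ccccc34)cc2)C1`): 1000000 nM
- compound 2 (`Cc1cc(COc2ccc(S(=O)(=O)NC3(CC(=O)NO)CN(C(=O)CC(C)C)C3)cc2)c2ccccc2n1`): 900000 nM
- compound 3 (`CCCCN1CC(CC(=O)NO)(NS(=O)(=O)c2ccc(OCc3cc(C)nc4ccccc34)cc2)C1`): 4900000 nM

Compound 3 stands highest of the three in this assay, and the other two numbers both lie lower by more than the scatter. The next compound, compound 4 (`Cc1cc(COc2ccc(S(=O)(=O)NC3(CC(=O)NO)CN(C(=O)OC(C)C)C3)cc2)c2ccccc2n1`), carries isopropoxycarbonyl in place of butyl on an amine nitrogen in a ring. Among the measured compounds shown here, one measured step bears directly on this change, namely a 5.4-fold higher number from compound 2 to compound 3 (0.74 log units; beyond the scatter), a modest step beyond the scatter in which butyl replaced isobutylcarbonyl on that same nitrogen. The change to compound 4 runs the other way, from butyl back to a group with a carbonyl, so a step of similar size towards a lower number is expected. For the measured compounds named here, this rests on a single step, and no measured compound yet carries isopropoxycarbonyl. The expected change is a 4.9-fold lower number from compound 3 to compound 4 (0.69 log units; beyond the scatter). For compound 4 the estimated value is 1000000 nM, with an expected range from 350000 nM to 2800000 nM.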

Compound 4, solubility: 1100000 nM
Compound 4: the middle estimate sits 1.1-fold (0.04 log units) below what was measured; the measured number falls inside the stated range.
By their numbers in this assay, from the lowest: compounds 2, 1 and 4 (each within the scatter of the next); then compound 3.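

On the amine nitrogen in the four-membered ring, a second group with a carbonyl now stands against butyl, and isopropoxycarbonyl in place of butyl gives a 4.5-fold lower number from compound 3 to compound 4 (0.65 log units; beyond the scatter) in this assay as the reading for this change. Isopropoxy in place of isobutyl on the carbonyl carbon gives a 1.2-fold higher number from compound 2 to compound 4 (0.09 log units; within the scatter) and so leaves the two carbonyl-bearing groups indistinguishable here, with butyl alone standing apart from both. The data offer no measured explanation for this difference on the ring nitrogen.

Among the compounds shown here, with butyl as the only group without a carbonyl at this position, it remains open whether other such groups would behave alike. A shorter chain such as ethyl, or a chain ending in a carboxylic acid or an amine, would test how far this holds.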